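The source may hold more compounds than are shown below. What is called first, only, known or untested is meant among the compounds shown, and "the series" means these compounds.

Measured in an assay on HEK293 cells for binding affinity to Urotensin-2 receptor (Homo sapiens), read by radioligand binding; on this read-out higher numbers stand for weaker inhibition and lower numbers for stronger inhibition:
compound 1 `Cc1cc(C(=O)N[C@H]2CCN(Cc3ccc(OCCCN(C)C)cc3)C2)ccc1Br` gives 631 nM
compound 2 `CC(C)C[C@H](NC(=O)c1ccc(Cl)c(Cl)c1)C(=O)N[C@H]1CCN(Cc2ccc(OCCCN(C)C)cc2)C1` gives 126 nM

Compound 2 stands with the lower of the two numbers in this assay; compound 1 sits higher by a gap that lies beyond the usual scatter. Among the measured compounds shown here, no single-point step between the two measured compounds is available, so the pair tells only that much and does not bear on the change considered next.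

Compound 3 `CC(C)C[C@H](NC(=O)c1ccncc1)C(=O)N[C@H]1CCN(Cc2ccc(OCCCN(C)C)cc2)C1` is not yet measured. It differs from compound 2 by pyridin-4-yl in place of 3,4-dichlorophenyl on a carbonyl carbon. For the measured compounds named here, nothing among the measured compounds tests this exchange, so the expectation rests on the structural change alone. A weakening, that is a higher number in this assay, of a size beyond the scatter is expected; the estimated step is a 7.9-fold higher number from compound 2 to compound 3 (0.90 log units; beyond the scatter). Compound 3 is expected to give about 1000 nM, within a range from 200 nM to 5000 nM.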

Compound 3, inhibition constant: 2000 nM
Compound 3: the middle estimate sits 2.0-fold (0.30 log units) below what was measured; low and high end bracket the measured number.
By their numbers in this assay, from the lowest: compound 2; then compound 1; then compound 3.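

Pyridin-4-yl in place of 3,4-dichlorophenyl on a carbonyl carbon is not tolerated without loss: in this assay the exchange gives a 16-fold higher number from compound 2 to compound 3 (1.20 log units; beyond the scatter), a large step beyond the scatter. Among the compounds shown here, this is the first single-point read on this position, and it shows that the number here depends strongly on the group carried by the carbonyl. The exchange removes both chlorine atoms and brings in a ring nitrogen with one hydrogen-bond acceptor, and no measured evidence explains the rise.

For the compounds shown here, the single step does not separate the loss of the chlorine atoms from the entry of the ring nitrogen, so it remains open which of the two carries the change. A plain phenyl group, or phenyl with a single chlorine, on the same carbonyl carbon would divide the step into its parts.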